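Phenoxy chain length on a thiazole-acid prostaglandin scaffold

The source may hold more compounds than are shown below. What is called first, only, known or untested is meant among the compounds shown, and "the series" means these compounds.

Compound 2 `O=C(O)c1csc([C@H]2CC[C@@H]3[C@@H](/C=C/CCCOc4ccccc4)[C@H](O)C[C@@H]3O2)n1` is measured in a functional assay on Chem1 cells for agonist activity at prostaglandin F2-alpha receptor (Homo sapiens), read by fluorescence and calcium flux (a lower number here means that less compound is needed, a higher number that more compound is needed for the effect), where compound 2 gives 8500 nM. Compound 1 `O=C(O)c1csc([C@H]2CC[C@@H]3[C@@H](/C=C/COc4ccccc4)[C@H](O)C[C@@H]3O2)n1` shares the core of compound 2 and differs by phenoxy in place of 2-phenoxyethyl on a saturated chain carbon bound to a double-bonded chain carbon. In this assay compound 1 gives only a limit, > 10000 nM, a limit marked by the limit of > 10000 nM in this assay, at which 1 of the 3 values shown sits. The step of an at least 1.1-fold higher number from compound 2 to compound 1 (0.07 log units; that floor lies within the scatter) is therefore only a floor. Compound 3 `O=C(O)c1csc([C@H]2CC[C@@H]3[C@@H](CCCCCOc4ccccc4)[C@H](O)C[C@@H]3O2)n1` has a core whose difference from compound 2 is not broken down here, and in this assay compound 3 gives "not determined" (no result reported). Compound 4 `O=C(O)c1csc([C@H]2CC[C@@H]3[C@@H](CCCOc4ccccc4)[C@H](O)C[C@@H]3O2)n1` differs from compound 3 by phenoxy in place of 2-phenoxyethyl on a saturated chain carbon, three bonds along the chain from a saturated ring carbon; this is the same kind of change as that from compound 2 to compound 1, but it sits three bonds along the chain from a saturated ring carbon rather than bound to a double-bonded chain carbon. With compound 3 unmeasured, compound 4 is expected, on the weak values of compound 1 and compound 2, to give about 15000 nM in this assay, most likely as a limit again.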

Compound 4, half-maximal effective concentration: > 10000 nM
Compound 4: no number, only a limit; the forecaster's own chance of this, stated with the estimate: 60%; the middle value lies beyond the limit too.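

Compound 4 gives only a limit in this assay, > 10000 nM. Among these compounds, compound 3 has no number, so no step between compound 3 and compound 4 can be read. The compounds shown leave open how chain length affects the saturated-chain compounds.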